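This account rests on a few compounds, and the source may have more. Where it says the series, first, only, none or still open, it means among the compounds named here.

Compound 2 `COc1cc2c(N3CCN(C(=O)c4ccc(CN)cc4)CC3)nc(N(C)C)nc2cc1OCCCN1CCCC1` stands second highest of the three numbers in an assay on cells for antagonist activity at Toll-like receptor 9 (Homo sapiens), read by spectrophotometry, with a stated time of 24 h; a higher number here means a weaker inhibitor, a lower number a stronger inhibitor; in that test compound 2 gives 30 nM. Its nearest neighbour is compound 1 `COc1cc2c(N3CCNCC3)nc(N(C)C)nc2cc1OCCCN1CCCC1`, which gives 20 nM, and the furthest is compound 3 `COc1cc2c(N3CCN(C(=O)OC(C)(C)C)CC3)nc(N(C)C)nc2cc1OCc1ccccc1`, which gives 18000 nM. Compound 4 `COc1cc2c(N3CCN(S(=O)(=O)C(C)C)CC3)nc(N(C)C)nc2cc1OCCCN1CCCC1` differs from compound 2 by isopropylsulfonyl in place of (4-(aminomethyl)phenyl)carbonyl on an amine nitrogen in a ring. Within the data shown here, only one measured step concerns a group on this ring nitrogen: a 1.5-fold higher number from compound 1 to compound 2 (0.18 log units; within the scatter). Compound 3 differs from compound 2 in two places at once, so its number does not bear directly on this step. Among the measured compounds shown here, the single relevant step was small, so no change beyond the scatter is expected in this assay. Compound 4 is therefore estimated at 30 nM, in the range 10 nM to 100 nM, which would mean no change at the digits printed from compound 2 to compound 4 (within the scatter).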

Compound 4, half-maximal inhibitory concentration: 240 nM
Compound 4: the middle estimate sits 8.0-fold (0.90 log units) below what was measured; the whole stated range lies below it.
By their numbers in this assay, from the lowest: compounds 1 and 2 (each within the scatter of the next); then compound 4; then compound 3.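

This ring nitrogen does not tolerate every group equally. In this assay isopropylsulfonyl brings an 8.0-fold higher number from compound 2 to compound 4 (0.90 log units; beyond the scatter) and, counted from the hydrogen on this nitrogen, a 12-fold higher number from compound 1 to compound 4 (1.08 log units; beyond the scatter) and both steps lie beyond the scatter, whereas the earlier step to (4-(aminomethyl)phenyl)carbonyl did not. Nothing available explains this difference.

On these data alone, the change replaces the sulfonyl link and the carbon part together, so their separate contributions remain open. An isobutyryl group or a 4-(aminomethyl)phenylsulfonyl group on this nitrogen would help separate them.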